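The source may report more compounds than this note shows. Statements on the series, on what has been measured and on what is new or still open speak of the compounds shown alone.

Measured so far:
- compound 1 `CCN(CC)c1ccc(-c2cccc(OC)c2)nn1`: > 25000 nM (a limit)
- compound 2 `CCN(CC)c1ccc(-c2cccc(Cl)c2)nn1`: > 25000 nM (a limit)

Both entries come from a functional assay on PC-3 cells (Homo sapiens) for antiproliferative activity, with a stated time of 48 h; on this read-out higher numbers stand for weaker inhibition and lower numbers for stronger inhibition. In this assay compound 2 gives > 25000 nM, which is a limit and not a number. Compound 1 gives > 25000 nM, also a limit. The series therefore stands at the limit of > 25000 nM in this assay, at which 2 of the 2 values shown sit, and no measured number is yet available for either compound.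

The next change leads to compound 3 `CCN(CC)c1ccc(-c2cccc(C(F)(F)F)c2)nn1`, with trifluoromethyl in place of chloro on an aromatic carbon.

For the measured compounds named here, the only measured step that bears on this change is a step that the two limits leave unreadable from compound 1 to compound 2. It also concerns a group exchanged on an aromatic carbon, but it gives no size to carry forward and no direction. With no readable step to build on, no real shift is expected, and compound 3 is expected to stay near the limit of this assay.

The expected step is a number no higher from compound 2 to compound 3 (the limit leaves the size open). The estimate for compound 3 is 25000 nM, with an expected range from 10000 nM to 40000 nM.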

Compound 3, half-maximal inhibitory concentration: > 25000 nM
Compound 3: only a limit was reported (the forecaster's own chance of this, stated with the estimate: 80%); the middle value sits exactly at the limit.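

In this assay compound 3 gives > 25000 nM, a limit and not a number. The steps among compound 1, compound 2 and compound 3 therefore cannot be read, and the series stands thus: the limit of > 25000 nM in this assay, at which 3 of the 3 values shown sit.

Still open is whether methoxy, chloro and trifluoromethyl on the aromatic carbon differ at all in this assay, since no compound shown gives a measured number.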